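The source may hold more compounds than are shown below. What is called first, only, known or untested is meant among the compounds shown, and "the series" means these compounds.

Compound 2 `Nc1cc(N)c2nc(-c3ccccc3)c(NCc3ccc(F)cc3)nc2c1` is measured in a functional assay on NCI-H226 cells (Homo sapiens) for inhibition, read by sulforhodamine B assay, with a stated time of 48 h (on this read-out higher numbers stand for lower toxicity in this test and lower numbers for higher toxicity in this test), only as a limit of the assay: compound 2 gives < 100000 nM. Among the compounds with values here, the one neighbour with a number is compound 1 `COc1ccc(CNc2nc3cc(N)cc(N)c3nc2-c2ccccc2)cc1OC`, which in this assay gives 64600 nM. The step from compound 1 to compound 2 is a step that the limit leaves unreadable from compound 1 to compound 2, its size hidden because the limit of < 100000 nM in this assay, at which 1 of the 2 values shown sits, caps the second value. Compound 3 `COc1ccc(CNc2nc3cc(N)cc(N)c3nc2-c2ccccc2)cc1` is not yet measured in this assay. It differs from compound 2 by methoxy in place of fluoro on an aromatic carbon. Within the data shown here, the only measured step does not set a readable size, and compound 3 sits structurally between compound 1 and compound 2, one methoxy short of compound 1. A step from compound 2 to compound 3 of about a step that the limit leaves unreadable from compound 2 to compound 3 is therefore expected, nothing beyond the scatter. Compound 3 is estimated at 70000 nM in this assay, with a range from 30000 nM to 150000 nM, and a real chance that only a limit is reported.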

Compound 3, concentration lethal to 50% of the cells: < 100000 nM
Compound 3: no number, only a limit (the forecaster's own chance of this, stated with the estimate: 45%); the middle value does not contradict the limit.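

No new step can be read among compound 1, compound 2 and compound 3 in this assay, since compound 2 and compound 3 are reported only as limits: the limit of < 100000 nM in this assay, at which 2 of the 3 values shown sit. The compounds shown leave open whether 4-fluorobenzyl and 4-methoxybenzyl differ at all on this read-out, or whether either differs from the group carried by compound 1.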